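Cyclopropyl in place of ethyl: plasma exposure in four analogues

The compounds below may be only part of what the source reports. "The series", "measured", "known", "first", "only" and "open" are said of these compounds alone.

Measured compounds:
compound 1, `O=C(O)c1cn(C2CC2)c2c(C(F)(F)F)c(N3CCN(c4ncccn4)CC3)c(F)cc2c1=O`, 14700 nM
compound 2, `CCn1cc(C(=O)O)c(=O)c2cc(F)c(N3CCN(c4ncccn4)CC3)c(C(F)(F)F)c21`, 11700 nM
compound 3, `CCn1cc(C(=O)O)c(=O)c2cc(F)c(N3CCN(c4ccccn4)CC3)c(C(F)(F)F)c21`, 14500 nM

These values come from an in vivo ADME assay on the whole organism for pharmacokinetics, with Rattus norvegicus as the target, at a dose of 20 mg/kg; a higher number here means more compound in the circulation at the dose given, a lower number less compound in the circulation. Compound 4, `O=C(O)c1cn(C2CC2)c2c(C(F)(F)F)c(N3CCN(c4ccccn4)CC3)c(F)cc2c1=O`, has not yet been measured there. Compound 4 differs from compound 3 by cyclopropyl in place of ethyl on an aromatic nitrogen. The same change, (cyclopropyl in place of ethyl on an aromatic nitrogen), has already been made once among these compounds and gave a 1.3-fold higher number from compound 2 to compound 1 (0.10 log units; within the scatter). The two places match word for word, so this is the same change carried out on two cores. The cores themselves differ by pyridin-2-yl in place of pyrimidin-2-yl on an amine nitrogen in a ring, a change that gave a 1.2-fold higher number from compound 2 to compound 3 (0.09 log units; within the scatter). All three measured values lie within the scatter of one another, and nothing in them sets compound 3 apart from compound 2 as a starting point for this change. For the measured compounds named here, for compound 4 a step of about a 1.2-fold higher number from compound 3 to compound 4 (0.07 log units; within the scatter) is expected, beside the earlier one, because the only precedent is a 1.3-fold higher number from compound 2 to compound 1 (0.10 log units; within the scatter) and that step stayed within the scatter. The estimate for compound 4 is therefore 17000 nM, with a range from 8000 nM to 35000 nM in which most repeats should fall.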

Compound 4, maximal plasma concentration: 12200 nM
Estimate against measurement, compound 4: 1.4-fold (0.14 log units) above; measured number inside the range.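

In this assay, cyclopropyl in place of ethyl on the aromatic nitrogen gives a 1.2-fold lower number from compound 3 to compound 4 (0.08 log units; within the scatter), and pyridin-2-yl in place of pyrimidin-2-yl on the amine nitrogen in a ring gives a 1.2-fold lower number from compound 1 to compound 4 (0.08 log units; within the scatter). Carried from one core to the other, the cyclopropyl change shows no difference that can be told from the scatter: the same change on two cores in this assay, a 1.3-fold higher number (0.10 log units; within the scatter) from compound 2 to compound 1 and a 1.2-fold lower number (0.08 log units; within the scatter) from compound 3 to compound 4, 1.5-fold (0.17 log units) apart, within the scatter of two such steps The same holds for the pyridin-2-yl change, but with every step inside the scatter, this shows only that neither change stands out on these two cores, not that a real effect of either change transfers between them: the same change on two cores in this assay, a 1.2-fold higher number (0.09 log units; within the scatter) from compound 2 to compound 3 and a 1.2-fold lower number (0.08 log units; within the scatter) from compound 1 to compound 4, 1.5-fold (0.17 log units) apart, within the scatter of two such steps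

Still open, as far as these compounds go, is whether a longer chain such as n-butyl on the aromatic nitrogen, or a phenyl group in place of pyridin-2-yl on the amine nitrogen, would give a step beyond the scatter on either core. If one did, the series could then test whether a step of that size carries from one core to the other.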